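The compounds below may be only part of what the source reports. "The series", "measured", "known", "first", "only" and "open" are said of these compounds alone.

Measured in a functional assay on P338 cells (Mus musculus) for antiproliferative activity; on this read-out lower numbers stand for stronger inhibition and higher numbers for weaker inhibition:
compound 1 `COc1cc(/C=C/C(=O)c2ccc(OCCn3cc(CN4C(=O)/C=C/C(C)(C)C/C=C(\C)CC/C=C/4C)nn3)cc2O)cc(OC)c1OC`: 0.89 ug/mL
compound 2 `C/C1=C\CC(C)(C)/C=C/C(=O)N(Cc2cn(CCOc3ccc(C(=O)/C=C/c4ccc(C)cc4)c(O)c3)nn2)/C(C)=C/CC1`: 0.92 ug/mL
compound 3 `COc1cc(/C=C/C(=O)c2ccc(OCCCN3C(=O)/C=C/C(C)(C)C/C=C(\C)CC/C=C/3C)cc2)cc(OC)c1OC`: 0.77 ug/mL

Compound 4 `C/C1=C\CC(C)(C)/C=C/C(=O)N(CCCOc2ccc(C(=O)/C=C/c3ccc(C)cc3)cc2)/C(C)=C/CC1` awaits measurement in this assay. The three measured numbers sit within the scatter of one another, so no order among them is claimed.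

The change already seen once, (4-methylphenyl in place of 3,4,5-trimethoxyphenyl on a double-bonded chain carbon bound to a double-bonded chain carbon), gave a 1.0-fold higher number from compound 1 to compound 2 (0.01 log units; within the scatter). The same change is now made on the other core: 4-methylphenyl in place of 3,4,5-trimethoxyphenyl on a double-bonded chain carbon bound to a double-bonded chain carbon. The two place descriptions agree word for word; how the core of compound 1 and the core of compound 3 differ is not broken down here.

Compound 4 is expected to show a 1.0-fold higher number from compound 3 to compound 4 (0.02 log units; within the scatter), because a 1.0-fold higher number from compound 1 to compound 2 (0.01 log units; within the scatter) stayed within the scatter and the position of the change is unchanged. The estimate for compound 4 is 0.8 ug/mL, with an expected range from 0.4 ug/mL to 1.6 ug/mL.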

Compound 4, half-maximal inhibitory concentration: 1.29 ug/mL
Estimate against measurement, compound 4: 1.6-fold (0.21 log units) below; measured number inside the range.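

Putting 4-methylphenyl in place of 3,4,5-trimethoxyphenyl on a double-bonded chain carbon bound to a double-bonded chain carbon gives, in this assay, a 1.7-fold higher number from compound 3 to compound 4 (0.22 log units; within the scatter), so the step stays within the scatter on this core as well. The two cores cannot be told apart in their response to the change: the same change on two cores in this assay, a 1.0-fold higher number (0.01 log units; within the scatter) from compound 1 to compound 2 and a 1.7-fold higher number (0.22 log units; within the scatter) from compound 3 to compound 4, 1.6-fold (0.21 log units) apart, within the scatter of two such steps. Across these two pairs the change carries over without a step beyond the scatter in this assay, but this shows neither a real effect of the change nor that it would behave alike on any other core.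

Still open, as far as these compounds go, is whether a phenyl bearing an amine or a carboxylic acid, at the same place, would give a step beyond the scatter. From the compounds shown here alone, the effect of a longer chain joining the two halves of the molecule also stays open.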